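Swapping the amide ring: from compound 3 to compound 4

The compounds below may be only part of what the source reports. "The series", "measured", "known", "first", "only" and "open" are said of these compounds alone.

In a functional assay on MDA-MB-231 cells (Homo sapiens) for inhibition, read by MTT assay (a higher number here means a weaker inhibitor of growth, a lower number a stronger inhibitor of growth), compound 1 `CC1=C(/C=C/C(C)=C/C=C/C(C)=C\C(=O)NCc2ccc(F)cc2)C(C)(C)CCC1n1ccnc1` gives 1410 nM.
In this assay compound 2 `CC1=C(/C=C/C(C)=C/C=C/C(C)=C\C(=O)Nc2ccc(F)cc2)C(C)(C)CCC1n1ccnc1` gives 4950 nM.
In this assay compound 3 `CC1=C(/C=C/C(C)=C/C=C/C(C)=C\C(=O)Nc2ccccc2O)C(C)(C)CCC1n1ccnc1` gives 4670 nM.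

Compound 3 holds the second highest of the three numbers; compound 2 sits within the scatter of it, while compound 1 stands apart, as a 3.3-fold higher number from compound 1 to compound 3 (0.52 log units; beyond the scatter) shows. Compound 4 `CC1=C(/C=C/C(C)=C/C=C/C(C)=C\C(=O)Nc2cccc(F)c2)C(C)(C)CCC1n1ccnc1` differs from compound 3 in one place: 3-fluorophenyl in place of 2-hydroxyphenyl on an amide-type nitrogen. The step that bears on this is a 1.1-fold lower number from compound 2 to compound 3 (0.03 log units; within the scatter), which shows two different rings on the amide-type nitrogen giving nearly the same number. The steps of a 3.5-fold higher number from compound 1 to compound 2 (0.55 log units; beyond the scatter) and a 3.3-fold higher number from compound 1 to compound 3 (0.52 log units; beyond the scatter) involve 4-fluorobenzyl and speak less directly to this change. The step to compound 4 is therefore expected to be a 1.0-fold higher number from compound 3 to compound 4 (0.00 log units; within the scatter), within the scatter. Compound 4 is estimated at 4700 nM, with a range from 2000 nM to 11000 nM.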

Compound 4, concentration for 50% growth inhibition: 8510 nM
Compound 4: the middle estimate sits 1.8-fold (0.26 log units) below what was measured, and the stated range covers the measured number.
By their numbers in this assay, from the lowest: compound 1; then compounds 3, 2 and 4 (each within the scatter of the next).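

In this assay, 3-fluorophenyl on the amide-type nitrogen stays within the scatter of both other rings attached there (a 1.8-fold higher number from compound 3 to compound 4 (0.26 log units; within the scatter); a 1.7-fold higher number from compound 2 to compound 4 (0.24 log units; within the scatter)), so these three rings cannot be told apart, although 2-hydroxyphenyl has a hydrogen-bond donor and 3-fluorophenyl has none. The 4-fluorobenzyl of compound 1 now stands further apart from an aryl amide (a 6.0-fold higher number from compound 1 to compound 4 (0.78 log units; beyond the scatter)). Nothing available explains these numbers. Still open, from the compounds shown here alone, is how a longer chain such as 2-phenylethyl would read on this nitrogen, or a phenyl ring carrying an amine or a carboxylic acid.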